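Arylthio quinoxaline diamines: growth inhibition notes

A few compounds are considered here, and "the series" means these few. Any claim that something is new, unique, unknown or untested is made for them only; others in the source may bear on it.

Measured compounds:
compound 1 `CCOC(=O)[C@H](CCC(=O)O)NC(=O)c1ccc(Sc2nc3cc(N)cc(N)c3nc2-c2ccccc2)cc1` — 21400 nM
compound 2 `Nc1cc(N)c2nc(-c3ccccc3)c(Sc3ccc(F)cc3)nc2c1` — 14800 nM
compound 3 `COc1cc(CNc2nc3cc(N)cc(N)c3nc2-c2ccccc2)cc(OC)c1OC` — 9770 nM

In a functional assay on HCT-116 cells (Homo sapiens) for inhibition, read by sulforhodamine B assay, with a stated time of 48 h (on this read-out lower numbers stand for stronger inhibition of growth and higher numbers for weaker inhibition of growth), compound 2 gives 14800 nM. Among the measured compounds shown here, on the numbers so far it sits between compound 1 and compound 3, yet its gaps to both lie within the scatter, so no ordering among the three is claimed. All three share a core that differs only in the group attached to it.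

Compound 4 `Nc1cc(N)c2nc(-c3ccccc3)c(Sc3ccc(Cl)c(Cl)c3)nc2c1` is not yet measured. It differs from compound 2 by 3,4-dichlorophenyl in place of 4-fluorophenyl on a sulfur. No comparable change exists among the measured compounds, so the direction of any step is open; the expectation is a step of small size, not beyond the scatter, a 1.5-fold lower number from compound 2 to compound 4 (0.17 log units; within the scatter). Compound 4 is therefore estimated at 10000 nM, with a range from 4000 nM to 30000 nM.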

Compound 4, concentration for 50% growth inhibition: 9330 nM
Compound 4: the middle estimate sits 1.1-fold (0.03 log units) above what was measured, and the stated range covers the measured number.
By their numbers in this assay, from the lowest: compounds 4, 3, 2 and 1 (each within the scatter of the next, the first and the last beyond it).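

In this assay, among the compounds shown here, the first step that differs in one place is a 1.6-fold lower number from compound 2 to compound 4 (0.20 log units; within the scatter), so 3,4-dichlorophenyl in place of 4-fluorophenyl on this sulfur gives no readable change in growth inhibition. At this position, the two halogenated aryl groups cannot be ordered. No measurement here offers a reason for the size of this step.

Going by these compounds, whether a butyl chain on the sulfur, or a nitrile on its phenyl ring, would move the number beyond the scatter remains open. On these data alone, the effect of changing the phenyl group on the shared core is also open.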